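A few compounds are considered here, and "the series" means these few. Any claim that something is new, unique, unknown or untested is made for them only; others in the source may bear on it.

Measured compounds in a functional assay on MV cells (Homo sapiens) for inhibition, read by sulforhodamine B assay; on this read-out lower numbers stand for stronger inhibition and higher numbers for weaker inhibition:
- compound 1, `C#CC(=O)N1C(c2cccc(F)c2)SC[C@@H]1C(=O)OCC`, gives 1700 nM
- compound 2, `C#CC(=O)N1C(C(CC)CCCC)SC[C@@H]1C(=O)OCC`, gives 1600 nM
- compound 3, `C#CC(=O)N1C(CC(C)CC(C)(C)C)SC[C@@H]1C(=O)OCC`, gives 1100 nM

Compound 3 carries the smallest of the three numbers, but compound 2 and compound 1 both lie within the scatter of it, so no ranking among the three follows. Going by the values given here, the one direct step, a 1.1-fold lower number from compound 1 to compound 2 (0.03 log units; within the scatter), shows that exchanging the group on the ring carbon left this assay essentially unchanged.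

Compound 4, `C#CC(=O)N1C(CCCC)SC[C@@H]1C(=O)OCC`, differs from compound 3 by propyl in place of 1,3,3-trimethylbutyl on a saturated chain carbon bound to a saturated ring carbon. Among the compounds with values here, no measured step covers a shortening of this chain, so the only bearing evidence is indirect: across three quite different groups at this position, this assay has moved little. Compound 4 is therefore expected to show no step beyond the scatter, at most a modest rise in the number; this expectation amounts to a 1.4-fold higher number from compound 3 to compound 4 (0.13 log units; within the scatter). Compound 4 is estimated at 1500 nM, with a range from 700 nM to 3500 nM.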

Compound 4, half-maximal inhibitory concentration: 400 nM
Beside the measured number, compound 4's estimate is 3.8-fold (0.57 log units) above it, outside the stated range (below it).
By their numbers in this assay, from the lowest: compound 4; then compounds 3, 2 and 1 (each within the scatter of the next).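

In this assay, going by these compounds alone, the group on the saturated ring carbon proves able to move the number, which the earlier compounds did not show: butyl stands apart from all three earlier groups, with steps beyond the scatter (a 2.8-fold lower number from compound 3 to compound 4 (0.44 log units; beyond the scatter)), (a 4.0-fold lower number from compound 2 to compound 4 (0.60 log units; beyond the scatter)) and (a 4.3-fold lower number from compound 1 to compound 4 (0.63 log units; beyond the scatter)). Compounds 1, 2 and 3 remain within the scatter of one another despite their different groups, so the step belongs to compound 4 alone and not to a graded series. Nothing given here explains why this change lowers the number.

The compounds shown leave open whether a propyl or hexyl group on the ring carbon would lower the number further or raise it. They also leave open how a chain carrying an amine, or a carboxylic acid in place of the ethyl ester, would read.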